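This account rests on a few compounds, and the source may have more. Where it says the series, first, only, none or still open, it means among the compounds named here.

Working notes on the series, all read in a functional assay on Hep 3B2 cells (Homo sapiens) for inhibition, read by sulforhodamine B assay, with a stated time of 72 h (on this read-out lower numbers stand for stronger inhibition and higher numbers for weaker inhibition), throughout. Compound 1 (`C[C@H](Nc1nc(N)nc(N)c1C#N)c1nn(-c2cccc(S(C)(=O)=O)c2)c2cc(F)ccc12`) gives 19700 nM as a measured number. Compound 2 (`C[C@H](Nc1ncnc2[nH]cnc12)c1nn(-c2cccc(F)c2)c2cc(F)ccc12`) gives > 40000 nM as a limit of the assay, not a number. Compound 3 (`C[C@H](Nc1nc(N)nc2[nH]cnc12)c1nn(-c2cccnc2)c2cc(F)ccc12`) gives > 40000 nM as a limit too. Compound 2 thus stands at the limit of > 40000 nM in this assay, at which 2 of the 3 values shown sit, and has no number of its own. Compound 4 (`C[C@H](Nc1ncnc2[nH]cnc12)c1nn(-c2ccncc2)c2cc(F)ccc12`) carries pyridin-4-yl in place of 3-fluorophenyl on an aromatic nitrogen and is otherwise the same as compound 2. Among the measured compounds shown here, no measured step covers this change, so compound 2 with its limit of > 40000 nM is the only anchor in this assay. No shift beyond the scatter is expected from that anchor. The estimated step (a number no higher from compound 2 to compound 4 (the limit leaves the size open)) is accordingly small. For compound 4 the estimate is 40000 nM with an expected range from 15000 nM to 80000 nM as its spread, and a report as a limit is likely.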

Compound 4, half-maximal inhibitory concentration: 21400 nM
Estimate against measurement, compound 4: 1.9-fold (0.27 log units) above, within the range that was stated.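

In this assay, pyridin-4-yl in place of 3-fluorophenyl on this aromatic nitrogen gives an at least 1.8-fold lower number from compound 2 to compound 4 (0.27 log units; that floor lies within the scatter). Among the compounds shown here, this pair is the first read at this position on a shared core, and compound 4 gives a measured number, 21400 nM, so a ring with one hetero atom here can be read on the scale. The true size of the step stays open because compound 2 has only a limit: the limit of > 40000 nM in this assay, at which 2 of the 4 values shown sit.

Still open, going by these compounds, is how a phenyl ring bearing an amine or a carboxylic acid would read at this position. Also open, on these data alone, is whether pyridin-4-yl gives a comparable step on the core of compound 1.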